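Chloro on the propanoyl chain of compound 1

The source may hold more compounds than are shown below. What is called first, only, known or untested is meant among the compounds shown, and "the series" means these compounds.

Within the data shown here, in a functional assay for inhibition, with Homo sapiens as the target (on this read-out lower numbers stand for an effect already at smaller amounts and higher numbers for an effect only at larger amounts of compound), compound 1 (`CCC(=O)Nc1ccc(C2=NNC(=O)CC2)cc1`) gives 0.64 ug/mL as the only actual number so far. Compound 2 (`CC(=O)Nc1cccc(C2=NNC(=O)CC2)c1`) gives > 46.4 ug/mL and this is a limit of the assay, not a number. Compound 3 (`CC(Cl)C(=O)Nc1ccc(C2=NNC(=O)CC2)cc1`) differs from compound 1 by chloro in place of hydrogen on a saturated chain carbon bound to a carbonyl carbon and a saturated chain carbon and this turns propanoylamino into ((1-chloroethyl)carbonyl)amino. Among the measured compounds shown here, no measured step gauges this change, so the expectation in this assay stays loose: a small shift toward higher numbers, possibly none beyond the scatter. The expected step of a 1.6-fold higher number from compound 1 to compound 3 (0.19 log units; within the scatter) is therefore modest, and it starts from compound 1 at 0.64 ug/mL as the sole numerical anchor. For compound 3 the estimated value is 1 ug/mL with an expected range from 0.2 ug/mL to 6 ug/mL in this read-out.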

Compound 3, half-maximal effective concentration: 0.45 ug/mL
Estimate against measurement, compound 3: 2.2-fold (0.35 log units) above; the measured number falls inside the stated range.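

Among these compounds, the only step read so far, a 1.4-fold lower number from compound 1 to compound 3 (0.15 log units; within the scatter), shows that in this assay this saturated chain carbon takes chloro in place of hydrogen with no shift beyond the usual scatter. The propanoyl chain of compound 1 and the (1-chloroethyl)carbonyl chain of compound 3 therefore cannot be told apart on this read-out, and the series now has a second actual number. Among the compounds shown here, compound 2, at > 46.4 ug/mL, is a limit of the assay and not a number, and it differs from compound 1 in more than one place, so it gives no step.

As far as these compounds go, whether the same carbon would also accept a hydroxyl, an amine or a longer chain stays open. No data shown bear on why chloro leaves the value within the scatter.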